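The source may hold more compounds than are shown below. What is called first, only, known or untested is meant among the compounds shown, and "the series" means these compounds.

Measured so far:
Compound 1, `CCCCCC(=O)Nc1ccc(S(=O)(=O)Oc2ccccc2I)cc1`: 13000 nM
Compound 2, `CC(C)c1ccccc1OS(=O)(=O)c1ccc(NC(=O)C(C)(C)C)cc1`: 15000 nM

Two compounds share the same core and were tested in a functional assay on HT-29 cells (Homo sapiens) for antiproliferative activity, read by sulforhodamine B assay, with a stated time of 48 h; a lower number here means a stronger inhibitor, a higher number a weaker inhibitor. Compound 1 gives 13000 nM in this assay, and compound 2 gives 15000 nM in this assay. These two numbers lie within the scatter of each other, so compound 2 cannot be set apart from compound 1 on this evidence; both are weak inhibitors in this assay.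

The next compound, compound 3, `CC(C)(C)C(=O)Nc1ccc(S(=O)(=O)Oc2ccccc2I)cc1`, differs from compound 2 in one place: iodo in place of isopropyl on an aromatic carbon. The iodo group that enters is the same group that compound 1 carries at that position, while the rest of compound 3 is taken from compound 2. Among the compounds with values here, no step between measured compounds shows the effect of this exchange directly, but compound 1, which already carries the iodo group, gives 13000 nM in this assay, a number within the scatter of compound 2. The step from compound 2 to compound 3 is therefore expected to be small, a 1.2-fold lower number from compound 2 to compound 3 (0.06 log units; within the scatter), with no direction beyond the scatter. Compound 3 is expected to give about 13000 nM in this assay, within a range of 5000 nM to 35000 nM.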

Compound 3, half-maximal inhibitory concentration: 9500 nM
For compound 3 the middle estimate is 1.4-fold (0.14 log units) above the measured one; measured number inside the range.
By their numbers in this assay, from the lowest: compounds 3, 1 and 2 (each within the scatter of the next).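

In this assay, within the data shown here, iodo in place of isopropyl on an aromatic carbon, ortho to a large group, gives a 1.6-fold lower number from compound 2 to compound 3 (0.20 log units; within the scatter) and is the first direct reading of this position, where a group of 1 heavy atom and a group of 3 heavy atoms cannot be told apart. The other end of the molecule can now be read as well: tert-butyl in place of pentyl on a carbonyl carbon gives a 1.4-fold lower number from compound 1 to compound 3 (0.14 log units; within the scatter) and so also stays inside the usual scatter, which means neither exchange separates the compounds involved. No separate measurement is available to explain these results.

The compounds shown leave open whether any group at that aromatic carbon can move the number beyond the scatter, for instance an amine or a carboxylic acid in place of iodo. They also leave open whether a larger change on the carbonyl carbon, such as a longer chain or a phenyl ring in place of tert-butyl, would separate a compound from this group of three.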